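Compound 3: an aromatic group returns to the amide nitrogen

The source may hold more compounds than are shown below. What is called first, only, known or untested is meant among the compounds shown, and "the series" means these compounds.

In a functional assay on CLL cells (Homo sapiens) for cytotoxicity, read by MTT assay, with a stated time of 48 h (a lower number here means that less compound is needed, a higher number that more compound is needed for the effect), compound 1 `C=C(CC)C(=O)c1ccc(OCC(=O)Nc2cccc(C(=O)O)c2)c(Cl)c1Cl`, with 3-carboxyphenyl on an amide-type nitrogen of the shared core, gives 20600 nM. Compound 2 `C=C(CC)C(=O)c1ccc(OCC(=O)NC(CS)C(=O)OCC)c(Cl)c1Cl`, with 1-(ethoxycarbonyl)-2-sulfanylethyl at that place, gives 4800 nM, the lower of the two numbers. Going by the values given here, the only measured step, a 4.3-fold lower number from compound 1 to compound 2 (0.63 log units; beyond the scatter), is modest but beyond the scatter.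

Compound 3 `C=C(CC)C(=O)c1ccc(OCC(=O)Nc2ccc3nc[nH]c3c2)c(Cl)c1Cl` has not yet been measured. It carries 1H-benzimidazol-6-yl in place of 1-(ethoxycarbonyl)-2-sulfanylethyl on the amide-type nitrogen: 1H-benzimidazol-6-yl in place of 1-(ethoxycarbonyl)-2-sulfanylethyl on an amide-type nitrogen. Among the compounds with values here, the change puts an aromatic group back on that nitrogen, so the one measured step bears on it, read in reverse. Within the data shown here, that step, a 4.3-fold lower number from compound 1 to compound 2 (0.63 log units; beyond the scatter), involved a different aromatic group, and no measurement yet shows how 1H-benzimidazol-6-yl behaves. A modest move to a higher number in this assay is therefore expected, probably somewhat smaller than the measured step. The expected change is a 1.9-fold higher number from compound 2 to compound 3 (0.27 log units; within the scatter). For compound 3 the estimated value is 9000 nM, with an expected range of 3500 nM to 23000 nM.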

Compound 3, half-maximal effective concentration: 3200 nM
Compound 3: the middle estimate sits 2.8-fold (0.45 log units) above what was measured; measured number outside the range, below it.
By their numbers in this assay, from the lowest: compounds 3 and 2 (each within the scatter of the next); then compound 1.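

Putting an aromatic group back on the amide-type nitrogen did not bring back the higher number of compound 1. In this assay the move from the 1-(ethoxycarbonyl)-2-sulfanylethyl chain to 1H-benzimidazol-6-yl stays within the scatter (a 1.5-fold lower number from compound 2 to compound 3 (0.18 log units; within the scatter)), so among these compounds an aromatic group at this place is compatible with a number matching that of the chain, and the chain is not needed to reach it. The exchange of one aromatic group for another, by contrast, goes beyond the scatter (a 6.4-fold lower number from compound 1 to compound 3 (0.81 log units; beyond the scatter)), which shows that the identity of the aromatic group matters here, although no measurement offered here explains the difference.

The compounds shown do not separate the carboxylic acid of compound 1 from its phenyl ring, a question that plain phenyl or the ethyl ester of that acid on the same nitrogen would address. They also leave open which part of the chain in compound 2 counts, the sulfanyl group or the ethyl ester, and how a free carboxylic acid in place of that ester would compare.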